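Branching at the hydrazone carbon: isopropyl to tert-butyl

The source may report more compounds than this note shows. Statements on the series, on what has been measured and on what is new or still open speak of the compounds shown alone.

Measured so far:
compound 1 `C/C(=N\Nc1nc2ccccc2o1)c1cc(C)ncn1`, 110 nM
compound 2 `CC(C)/C(=N\Nc1nc2ccccc2o1)c1ccccn1`, 645 nM
compound 3 `C/C(=N\N(C)c1nc2ccccc2o1)c1ccccn1`, > 50000 nM

In a functional assay on HT-29 cells (Homo sapiens) for antiproliferative activity, read by sulforhodamine B assay (a lower number here means a stronger inhibitor, a higher number a weaker inhibitor), compound 2 gives 645 nM, the highest of the two numbers shown; compound 1 sits lower at 110 nM, a gap beyond the scatter. For compound 3 this assay reports only a limit, > 50000 nM, as noted in the limit of > 50000 nM in this assay, at which 1 of the 3 values shown sits.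

Compound 4 `CC(C)(C)/C(=N\Nc1nc2ccccc2o1)c1ccccn1` differs from compound 2 in one place: methyl in place of hydrogen on a saturated chain carbon bound to a carbon with a double bond to nitrogen and two saturated chain carbons. The unmeasured compound carries a larger saturated chain group at that carbon. Given that compound 2 already stands at 645 nM, the step of a 3.9-fold higher number from compound 2 to compound 4 (0.59 log units; beyond the scatter) is expected to weaken inhibition further, beyond the scatter. Compound 4 is estimated at 2500 nM, within 600 nM to 15000 nM.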

Compound 4, half-maximal inhibitory concentration: > 10000 nM
Compound 4 ended at the assay's limit; the forecaster's own chance of this, stated with the estimate: 10%; at least 4.0-fold (0.60 log units) between middle value and limit.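

In this assay, for the compounds shown here, isopropyl to tert-butyl at this carbon gives an at least 15-fold higher number from compound 2 to compound 4 (1.19 log units; beyond the scatter), the first one-place comparison and a large loss from a single added methyl. The result for compound 4 is a limit, not a number: the limit of > 10000 nM in this assay, at which 1 of the 4 values shown sits. The step therefore gives only a minimum size, and the position is shown to accept isopropyl far better than tert-butyl.

From the compounds shown here alone, whether ethyl, cyclopropyl or a longer chain at this carbon keeps the activity of compound 2 stays open. No one-place comparison here links isopropyl to methyl at this carbon.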